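A few compounds are considered here, and "the series" means these few. Any claim that something is new, unique, unknown or untested is made for them only; others in the source may bear on it.

Working notes on the series. Two compounds carry numbers in an assay on microsomes from liver (strain Wistar) for inhibition of acyl-CoA desaturase 1 (Rattus norvegicus), read by HPLC, with stated times of 1 h and 60 min; on this read-out lower numbers stand for stronger inhibition and higher numbers for weaker inhibition. Compound 1 `NC(=O)c1cnc(N2CCC(Sc3ccccc3C(F)(F)F)CC2)s1` gives 4 nM, and compound 2 `NC(=O)c1nnc(N2CCC(Oc3ccccc3C(F)(F)F)CC2)s1` gives 3 nM. The gap between them lies within the usual scatter, so neither stands apart; compound 2 merely sits at the lower end of this pair, and nothing is separated here beyond repeat variation.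

Compound 3 `NC(=O)c1n[nH]c(N2CCC(Oc3ccccc3C(F)(F)F)CC2)n1` has not been measured. It differs from compound 2 in one place: 3-carbamoyl-1H-1,2,4-triazol-5-yl in place of 5-carbamoyl-1,3,4-thiadiazol-2-yl on an amine nitrogen in a ring. No measured pair in the series shows this kind of change, so the step is not anchored by any shown comparison. The expectation is a modest move toward weaker inhibition in this assay, of a size that may just exceed the scatter. Compound 3 is estimated at 15 nM, with a range from 4 nM to 60 nM, which corresponds to an expected step of a 5.0-fold higher number from compound 2 to compound 3 (0.70 log units; beyond the scatter).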

Compound 3, half-maximal inhibitory concentration: 127 nM
Beside the measured number, compound 3's estimate is 8.5-fold (0.93 log units) below it; the whole stated range lies below it.
By their numbers in this assay, from the lowest: compounds 2 and 1 (each within the scatter of the next); then compound 3.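

In this assay the group on the amine nitrogen in a ring proves far from interchangeable: 3-carbamoyl-1H-1,2,4-triazol-5-yl in place of 5-carbamoyl-1,3,4-thiadiazol-2-yl gives a 42-fold higher number from compound 2 to compound 3 (1.63 log units; beyond the scatter) in a large step, although both groups hold 8 heavy atoms and one five-membered aromatic ring with 3 hetero atoms. The earlier pair could not show this, as compound 1 and compound 2 differ in more than one place. Nothing measured here bears on what lies behind the size of this step.

The change trades the ring sulfur for a nitrogen and also moves the counts from 1 hydrogen-bond donor and 4 acceptors to 2 donors and 3 acceptors, and the two compounds do not separate these differences. From the compounds shown here alone, a 5-carbamoyl-1,3,4-oxadiazol-2-yl group at this position, or a carboxylic acid in place of the carbamoyl group on either ring, remains open.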